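Swapping ethyl for 4-fluorophenyl: what to expect

A few compounds are considered here, and "the series" means these few. Any claim that something is new, unique, unknown or untested is made for them only; others in the source may bear on it.

Measured so far in an ADME assay on BHK cells (Mesocricetus auratus) for cytotoxicity, read by MTT assay, with a stated time of 96 h; on this read-out lower numbers stand for higher toxicity in this test and higher numbers for lower toxicity in this test
Compound 1 `O=[N+]([O-])c1ccc(NC(=S)Nc2cccc(C(F)(F)F)c2)cc1` gives 9500 nM
Compound 2 `FC(F)(F)c1cccc(NC(=S)Nc2ccccc2)c1` gives 41000 nM
Compound 3 `CCNC(=S)Nc1cccc(C(F)(F)F)c1` gives > 100000 nM as a limit

Compound 3 has only a limit (> 100000 nM) and no exact number. Compound 4 `Fc1ccc(NC(=S)Nc2cccc(C(F)(F)F)c2)cc1` carries 4-fluorophenyl in place of ethyl on an amide-type nitrogen. The closest measured change runs the opposite way, since ethyl in place of phenyl gave an at least 2.4-fold higher number from compound 2 to compound 3 (0.38 log units; beyond the scatter) as its result. Hydrogen in place of nitro gave a 4.3-fold higher number from compound 1 to compound 2 (0.64 log units; beyond the scatter) as a further guide. A clearly lower number is therefore expected, close to compound 2 (41000 nM). The expected step is an at least 3.7-fold lower number from compound 3 to compound 4 (0.56 log units; beyond the scatter) by this estimate. Compound 4 is estimated at 27000 nM with an expected range from 10000 nM to 70000 nM in this assay here.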

Compound 4, half-maximal cytotoxic concentration: 26000 nM
The estimate for compound 4 lay 1.0-fold (0.02 log units) above the measured number, and the stated range covers the measured number.
By their numbers in this assay, from the lowest: compound 1; then compounds 4 and 2 (each within the scatter of the next). At a limit, above all of these: compound 3.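

Putting 4-fluorophenyl in place of ethyl on the amide-type nitrogen gives an at least 3.8-fold lower number from compound 3 to compound 4 (0.58 log units; beyond the scatter). The value of compound 3 is a limit, not an exact number: the limit of > 100000 nM in this assay, at which 1 of the 4 values shown sits.

On the aromatic carbon, fluoro in place of hydrogen gives a 1.6-fold lower number from compound 2 to compound 4 (0.20 log units; within the scatter), so the two cannot be told apart, whereas fluoro in place of nitro gives a 2.7-fold higher number from compound 1 to compound 4 (0.44 log units; beyond the scatter), which shows that this carbon's substituent can matter with nitro but not with fluoro.

As far as these compounds go, whether an amine or a methoxy group on that aromatic carbon would stay level with fluoro and hydrogen remains open. So does the number that a longer chain such as butyl, or a cyclohexyl ring, would give on the amide-type nitrogen.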